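Bromo to fluoro on the benzyl group: cytotoxicity outlook

This account rests on a few compounds, and the source may have more. Where it says the series, first, only, none or still open, it means among the compounds named here.

Measured so far:
compound 1, `CC(=O)OC[C@H]1O[C@@H](CC(=O)/C=C2\C(=O)N(Cc3ccc(F)cc3)c3ccccc32)[C@H](OC(C)=O)[C@@H](OC(C)=O)[C@@H]1OC(C)=O`: 119000 nM
compound 2, `CC(=O)OC[C@H]1O[C@@H](CC(=O)/C=C2\C(=O)N(Cc3ccc(Br)cc3)c3ccc(Cl)cc32)[C@H](OC(C)=O)[C@@H](OC(C)=O)[C@@H]1OC(C)=O`: 93300 nM

Both compounds share the acetylated sugar and the benzylidene-oxindole core and were read in an ADME assay on Vero cells (Chlorocebus sabaeus) for cytotoxicity, read by resazurin assay, with a stated time of 72 h; a higher number here means that more compound is tolerated, a lower number that less compound is tolerated. In this assay compound 1 gives 119000 nM and compound 2 gives 93300 nM; the two numbers lie within the usual scatter of each other, so compound 2 does not stand apart from compound 1 on the numbers at hand. Within the data shown here, no single-point step between measured compounds is available.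

Compound 3, `CC(=O)OC[C@H]1O[C@@H](CC(=O)/C=C2\C(=O)N(Cc3ccc(F)cc3)c3ccc(Cl)cc32)[C@H](OC(C)=O)[C@@H](OC(C)=O)[C@@H]1OC(C)=O`, differs from compound 2 by fluoro in place of bromo on an aromatic carbon. Compound 1 also carries fluoro on the benzyl group and is close to compound 2 in this assay, so no step beyond the scatter is expected from compound 2 to compound 3; the expected step is a 1.1-fold higher number from compound 2 to compound 3 (0.05 log units; within the scatter). For compound 3 the estimate in this assay is 105000 nM, with a range from 55000 nM to 200000 nM.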

Compound 3, half-maximal cytotoxic concentration: 107000 nM
Beside the measured number, compound 3's estimate is 1.0-fold (0.01 log units) below it; low and high end bracket the measured number.
By their numbers in this assay, from the lowest: compounds 2, 3 and 1 (each within the scatter of the next).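

In this assay, among these compounds, fluoro in place of bromo on an aromatic carbon of the benzyl group, with the rest of compound 2 unchanged, gives a 1.1-fold higher number from compound 2 to compound 3 (0.06 log units; within the scatter) and thus provides the first direct reading at this position: 4-bromobenzyl and 4-fluorobenzyl cannot be told apart here when the chloro is present. Compound 3 also provides a single-point reading at the other varied place, where chloro in place of hydrogen on an aromatic carbon gives a 1.1-fold lower number from compound 1 to compound 3 (0.05 log units; within the scatter), so neither single change in this set moves the number beyond the scatter. No supporting data are available to explain these readings.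

The compounds shown carry only halogens on the benzyl group, so it remains open whether an amine, a carboxylic acid or a longer alkyl chain at the same place, para to a large group, would give a step beyond the scatter. From the compounds shown here alone, the effect of bromo against fluoro without the chloro also remains open, as does any change to the acetylated sugar, such as free hydroxyl groups in place of the acetates.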